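The source may report more compounds than this note shows. Statements on the series, on what has been measured and on what is new or still open speak of the compounds shown alone.

Compound 2 `Cc1cc(C)c(CN2CCc3c(Cl)cc(-c4c(C)noc4C)c(Cl)c3C2=O)c(=O)[nH]1` stands with the lowest number of the two compounds measured in an assay on cells for inhibition of histone-lysine N-methyltransferase EZH2 (Homo sapiens), read by ELISA, with a stated time of 72 h (a higher number here means a weaker inhibitor, a lower number a stronger inhibitor), where compound 2 gives 15 nM; compound 1 `Cc1cc(C)c(CN2CCc3c(Cl)cc(-c4cn[nH]c4)c(Cl)c3C2=O)c(=O)[nH]1` gives 1730 nM in this assay. Compound 3 `Cc1cc(C)c(CN2CCc3c(Cl)cc(-c4cn[nH]c4C)c(Cl)c3C2=O)c(=O)[nH]1` differs from compound 2 by 5-methyl-1H-pyrazol-4-yl in place of 3,5-dimethyl-1,2-oxazol-4-yl on an aromatic carbon. Going by the values given here, the one measured step that bears on this change, a 120-fold lower number from compound 1 to compound 2 (2.06 log units; beyond the scatter), ran in the opposite direction and was large. Compound 3 keeps a single methyl group on a ring that again carries a hydrogen-bond donor, so the number is expected to rise, by less than a full reversal, with the expected step of a 10-fold higher number from compound 2 to compound 3 (1.00 log units; beyond the scatter). In this assay compound 3 is estimated at 150 nM, in the range 30 nM to 900 nM.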

Compound 3, half-maximal inhibitory concentration in the histone-lysine N-methyltransferase EZH2 assay: 873 nM
For compound 3 the middle estimate is 5.8-fold (0.76 log units) below the measured one, within the range that was stated.
By their numbers in the histone-lysine N-methyltransferase EZH2 assay, from the lowest: compound 2; then compounds 3 and 1 (each within the scatter of the next).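

In the histone-lysine N-methyltransferase EZH2 assay compound 1 gives 1730 nM and compound 3 gives 873 nM and the added methyl alone gives no step beyond the scatter (a 2.0-fold lower number from compound 1 to compound 3 (0.30 log units; within the scatter)). The large gap therefore remains between the two methylated rings in the histone-lysine N-methyltransferase EZH2 assay (a 58-fold higher number from compound 2 to compound 3 (1.76 log units; beyond the scatter)), and this change shows no matching difference in a physicochemical assay for lipophilicity, at pH 7.4 (a lower number here means a more polar compound, a higher number a more lipophilic compound), where compound 2 gives 3.1 and compound 3 gives 3.1 (no change at the digits printed from compound 2 to compound 3 (within the scatter)). No evidence is at hand that accounts for this gap. The compounds shown leave open whether a 3,5-dimethyl-1H-pyrazol-4-yl group, carrying both methyl groups of the oxazole together with the ring hydrogen of the pyrazole, would stand nearer compound 2 or compound 3.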